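The compounds below may be only part of what the source reports. "The series", "measured", "known", "first", "only" and "open" are said of these compounds alone.

Measured so far in an ADME assay on WI-38 cells (Homo sapiens) for cytotoxicity, read by sulforhodamine B assay, with a stated time of 24 h; a higher number here means a weaker inhibitor, a lower number a stronger inhibitor: compound 1 `N/N=C1\C(=O)Nc2ccc(S(=O)(=O)N3CCOCC3)cc21` gives 391000 nM; compound 2 `O=C1Nc2ccc(S(=O)(=O)N3CCOCC3)cc2/C1=N/c1ccc(Cl)cc1` gives 468000 nM; compound 3 `CC(=O)c1cccc(/N=C2\C(=O)Nc3ccc(S(=O)(=O)N4CCOCC4)cc32)c1` gives 177000 nM.

Compound 3 stands lowest of the three numbers: a 2.2-fold lower number from compound 1 to compound 3 (0.34 log units; beyond the scatter) and a 2.6-fold lower number from compound 2 to compound 3 (0.42 log units; beyond the scatter) are both beyond the scatter, whereas a 1.2-fold higher number from compound 1 to compound 2 (0.08 log units; within the scatter) is within it.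

Compound 4 `O=C1Nc2ccc(S(=O)(=O)N3CCOCC3)cc2/C1=N/c1ccc(Br)cc1` differs from compound 3 by 4-bromophenyl in place of 3-acetylphenyl on a double-bonded nitrogen. The step bearing most on this is a 2.6-fold lower number from compound 2 to compound 3 (0.42 log units; beyond the scatter), run here in reverse, since the 4-chlorophenyl of compound 2 resembles the entering 4-bromophenyl and the leaving 3-acetylphenyl is what set compound 3 apart; a 2.2-fold lower number from compound 1 to compound 3 (0.34 log units; beyond the scatter) points the same way. A modest rise in this assay is therefore expected, about a 2.4-fold higher number from compound 3 to compound 4 (0.38 log units; beyond the scatter), back toward the number of compound 2. Compound 4 is estimated at 420000 nM, in the range 210000 nM to 840000 nM.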

Compound 4, half-maximal inhibitory concentration: 372000 nM
Beside the measured number, compound 4's estimate is 1.1-fold (0.05 log units) above it, and the stated range covers the measured number.
By their numbers in this assay, from the lowest: compound 3; then compounds 4, 1 and 2 (each within the scatter of the next).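

Bromo and chloro on an aromatic carbon cannot be told apart in this assay: a 1.3-fold lower number from compound 2 to compound 4 (0.10 log units; within the scatter). On the double-bonded nitrogen, 4-bromophenyl and amino also stay within the scatter of each other, a 1.1-fold lower number from compound 1 to compound 4 (0.02 log units; within the scatter). Among the groups at this position, 3-acetylphenyl alone stands apart, now against bromo as well, a 2.1-fold higher number from compound 3 to compound 4 (0.32 log units; beyond the scatter). No measurement at hand offers an explanation for this.

Open, going by these compounds, is whether the separation belongs to the acetyl group itself. A phenyl bearing an amine or a carboxylic acid in its place would test that.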